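Trifluoromethyl Added to a Core That Shows No Inhibition

The source may report more compounds than this note shows. Statements on the series, on what has been measured and on what is new or still open speak of the compounds shown alone.

compound 1, `Nc1nc2ccccn2c1-c1ccc(O)cc1`: > 100000 nM, a limit of the assay
compound 2, `CC(C)Nc1nc2ccccn2c1-c1ccc(O)cc1`: > 100000 nM, a limit of the assay

In an assay on isolated protein for inhibition of ubiquitin carboxyl-terminal hydrolase 14 (Homo sapiens) (on this read-out lower numbers stand for stronger inhibition and higher numbers for weaker inhibition), compound 1 gives only a limit and no number. Compound 2 likewise gives only a limit. The step that the two limits leave unreadable from compound 1 to compound 2 therefore cannot be read. Compound 3, `Nc1nc2ccc(C(F)(F)F)cn2c1-c1ccc(O)cc1`, differs from compound 1 by trifluoromethyl in place of hydrogen on an aromatic carbon. Among the compounds with values here, no measured step bears on this change. Because (the limit of > 100000 nM in this assay, at which 2 of the 2 values shown sit), compound 3 is expected to remain at the limit as well, with a step of a number no higher from compound 1 to compound 3 (the limit leaves the size open) expected to show nothing beyond the scatter. Compound 3 is estimated at 100000 nM, in the range 30000 nM to 300000 nM.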

Compound 3, half-maximal inhibitory concentration: > 100000 nM
Compound 3: only a limit was reported; the forecaster's own chance of this, stated with the estimate: 80%; the middle value lies on the limit itself.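

Compound 3 gives > 100000 nM, which is a limit and not a number; compound 1 also gives only a limit, and the step between them cannot be read. The compounds shown leave open whether any change to the shared core brings measurable inhibition in this assay.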